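Chloro-to-amino step on a second benzyl core

This account rests on a few compounds, and the source may have more. Where it says the series, first, only, none or still open, it means among the compounds named here.

Measured in a functional assay on M14 cells (Homo sapiens) for cytotoxicity, read by sulforhodamine B assay, with a stated time of 48 h; on this read-out lower numbers stand for stronger inhibition of growth and higher numbers for weaker inhibition of growth:
- compound 1, `ClCc1ccccc1Cn1cnc2c(Cl)nc(Cl)nc21`, gives 1380 nM
- compound 2, `ClCc1cccc(Cn2cnc3c(Cl)nc(Cl)nc32)c1`, gives 1770 nM
- compound 3, `Nc1nc(Cl)c2ncn(Cc3ccccc3CCl)c2n1`, gives 5750 nM

Compound 3 differs from compound 1 by amino in place of chloro on an aromatic carbon. That change made a step of a 4.2-fold higher number from compound 1 to compound 3 (0.62 log units; beyond the scatter). Compound 1 and compound 2 are built from the same atoms joined differently; the difference between the two cores is not broken down here. Their two values lie within the usual scatter of each other, so nothing is read from that pair.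

Compound 4, `Nc1nc(Cl)c2ncn(Cc3cccc(CCl)c3)c2n1`, has not been measured. It differs from compound 2 by amino in place of chloro on an aromatic carbon, which is the same change as from compound 1 to compound 3, with the place described in identical words. Among the compounds with values here, only one earlier instance of this change is available, so the expectation rests on that step alone, together with the closeness of compound 1 and compound 2. In this assay compound 4 is expected to sit about a 4.0-fold higher number from compound 2 to compound 4 (0.60 log units; beyond the scatter) from compound 2, beside the earlier 4.2-fold higher number from compound 1 to compound 3 (0.62 log units; beyond the scatter). The estimate for compound 4 is 7000 nM, with a likely range from 3000 nM to 16000 nM.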

Compound 4, concentration for 50% growth inhibition: 3630 nM
For compound 4 the middle estimate is 1.9-fold (0.29 log units) above the measured one; the range from low to high includes it.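

In this assay amino in place of chloro on an aromatic carbon again goes with a higher number on the second core, giving a 2.1-fold higher number from compound 2 to compound 4 (0.31 log units; beyond the scatter). The direction of the step therefore carries from the core of compound 1 to the core of compound 2, and the two step sizes cannot be told apart: the same change on two cores in this assay, a 4.2-fold higher number (0.62 log units; beyond the scatter) from compound 1 to compound 3 and a 2.1-fold higher number (0.31 log units; beyond the scatter) from compound 2 to compound 4, 2.0-fold (0.31 log units) apart, within the scatter of two such steps. Within the data shown here, this rests on only two pairs in a single cell line, so it does not show that the step has a fixed size, that it would carry to any further core, or why the number rises.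

The compounds shown leave open whether a methylamino or a methoxy group on that same aromatic carbon would go the way of amino. Also open, going by these compounds, is whether either core would keep its value with a hydroxymethyl group in place of the chloromethyl group.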